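The source may hold more compounds than are shown below. What is called first, only, known or untested is meant among the compounds shown, and "the series" means these compounds.

Working notes on a short series run in a functional assay with Rattus norvegicus as the target; a lower number here means a stronger inhibitor, a higher number a weaker inhibitor. Compound 1 `COc1cc(C(=O)/C=C/c2ccncc2)cc(OC)c1OC` gives 7000 nM and holds the lowest of the two numbers in hand. Compound 2 `O=C(c1ccccc1)c1cccc(-c2cccnc2)c1` gives about 100000 nM in this assay, a markedly higher number, beyond the usual scatter. Compound 3 `COc1cc(C(=O)/C=C(\C)c2ccncc2)cc(OC)c1OC` sits at the limit of > 100000 nM in this assay, at which 1 of the 3 values shown sits, and returns > 100000 nM, which is a limit of the assay and not a number. Within the data shown here, no two measured compounds differ in a single place, so no isolated step has been measured in this set.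

Compound 4 `COc1cc(C(=O)/C=C/c2ccccn2)cc(OC)c1OC` carries the same atoms as compound 1, joined differently: pyridin-2-yl in place of pyridin-4-yl on a double-bonded chain carbon bound to a double-bonded chain carbon. Nothing measured here isolates this change, so the size of the step is not known. The expected change in this assay is a 1.4-fold higher number from compound 1 to compound 4 (0.15 log units; within the scatter), a step judged small, at or near the edge of the scatter, with a modest weakening somewhat more likely than a gain. The estimate for compound 4 in this assay is 10000 nM, with a range from 3000 nM to 40000 nM.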

Compound 4, half-maximal inhibitory concentration: 18000 nM
Compound 4: the middle estimate sits 1.8-fold (0.26 log units) below what was measured, and the stated range covers the measured number.
By their numbers in this assay, from the lowest: compound 1; then compound 4; then compound 2.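

In this assay the series now has its first isolated step, and it shows that this place responds to where the ring nitrogen sits, even with the atoms of the group unchanged: pyridin-2-yl in place of pyridin-4-yl on a double-bonded chain carbon bound to a double-bonded chain carbon gives a 2.6-fold higher number from compound 1 to compound 4 (0.41 log units; beyond the scatter). Of the two groups compared on this chain, pyridin-4-yl therefore gives the lower number, though the step is not large. No measured property in hand bears on the reason for this step.

On these data alone, the reading rests on a single pair, so it remains open whether the order holds on any other core. As far as these compounds go, how a thiazol-2-yl ring or a carboxylic acid would behave at this place also remains open.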